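Methyl in Place of Hydrogen: Expected Exposure of Compound 4

The compounds below may be only part of what the source reports. "The series", "measured", "known", "first", "only" and "open" are said of these compounds alone.

Measured compounds:
Compound 1 `C[C@H](c1ccc(-c2cc(Cl)ccc2-c2nc(=O)o[nH]2)cc1)N(CC1CC1)c1nc2c(C(=O)O)cccc2o1`: 976 nM
Compound 2 `C[C@H](c1ccc(-c2ccccc2-c2nc(=O)o[nH]2)cc1)N(CC1CC1)c1nc2c(C(=O)O)cccc2o1`: 7710 nM
Compound 3 `CCCCN(c1nc2c(C(=O)NC)cccc2o1)[C@H](C)c1ccc(-c2ccccc2-c2nnn[nH]2)cc1`: 19.7 nM

In an ADME assay on the whole organism (Macaca fascicularis) for pharmacokinetics, read by LC-MS, using cassette dosing, at a dose of 1 mg/kg by the oral route (on this read-out higher numbers stand for higher exposure at the dose given and lower numbers for lower exposure), compound 2 gives 7710 nM, the highest of the three numbers. Its nearest neighbour is compound 1 with 976 nM, and the furthest is compound 3 with 19.7 nM; both gaps lie beyond the scatter.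

Compound 4 `Cc1ccc(-c2nc(=O)o[nH]2)c(-c2ccc([C@@H](C)N(CC3CC3)c3nc4c(C(=O)O)cccc4o3)cc2)c1` differs from compound 2 by methyl in place of hydrogen on an aromatic carbon. For the measured compounds named here, the one measured step that bears on this is a 7.9-fold higher number from compound 1 to compound 2 (0.90 log units; beyond the scatter), where removing a chloro from an aromatic carbon raised the exposure by a modest amount. Going by the values given here, putting a methyl back onto an aromatic carbon of compound 2 is therefore expected to move the number downward rather than upward, though no methyl analogue has been measured and the size of the step is uncertain.

On this basis the exposure of compound 4 in this assay is expected to be 2500 nM, with a plausible range from 700 nM to 8000 nM. This estimate corresponds to an expected step of a 3.1-fold lower number from compound 2 to compound 4 (0.49 log units; beyond the scatter).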

Compound 4, maximal plasma concentration: 2920 nM
Beside the measured number, compound 4's estimate is 1.2-fold (0.07 log units) below it; measured number inside the range.
By their numbers in this assay, from the lowest: compound 3; then compound 1; then compound 4; then compound 2.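

The result shows that the drop from losing hydrogen in this assay is not confined to chloro: a methyl on the same aromatic carbon also lowers the number, with a 2.6-fold lower number from compound 2 to compound 4 (0.42 log units; beyond the scatter) for this change. The two replacing groups also differ from each other, since a 3.0-fold higher number from compound 1 to compound 4 (0.48 log units; beyond the scatter) separates methyl from chloro, so that on this core the order at this position runs from hydrogen through methyl to chloro. Nothing measured here accounts for these steps.

Going by these compounds, whether a fluoro, a methoxy or an amine on this carbon would stay closer to hydrogen than methyl does remains open. So does whether a methyl on the other aromatic carbons of this ring, or on a core with the butyl chain of compound 3, would give a step of the same direction and size.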